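The source may hold more compounds than are shown below. What is called first, only, known or untested is meant among the compounds shown, and "the series" means these compounds.

Going by the values given here, in a functional assay on NCI-H460 cells (Homo sapiens) for cytotoxicity, read by sulforhodamine B assay, with a stated time of 3 days (on this read-out lower numbers stand for stronger inhibition and higher numbers for weaker inhibition), compound 2 `CC(=O)OCc1cn(Cc2ccc(Cl)cc2)c2ccccc12` gives 39 nM, the only actual number available so far. Compound 1 `OCCc1cn(Cc2ccc(Cl)cc2)c2ccccc12` gives only a limit, > 31600 nM. Compound 3 `Cc1cn(Cc2ccc(Cl)cc2)c2ccccc12` awaits measurement. Its difference from compound 2 is hydrogen in place of acetoxy on a saturated chain carbon bound to an aromatic carbon. Hydrogen thus stands in place of acetoxy on a saturated chain carbon bound to an aromatic carbon, so that acetoxymethyl becomes methyl.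

Among the compounds with values here, only one measured step bears on this change, and it is large: an at least 810-fold lower number from compound 1 to compound 2 (2.90 log units; beyond the scatter). In that step acetoxy entered in place of hydroxymethyl, whereas here acetoxy leaves and hydrogen enters, so the two changes are not exact mirror images. Even so, the single step on record points to a strong dependence on the acetoxy, and much of that gain is expected to be lost. A large move towards higher numbers is therefore expected in this assay, and the estimated step is a 150-fold higher number from compound 2 to compound 3 (2.19 log units; beyond the scatter). Compound 3 is estimated at 6000 nM, with an expected range from 600 nM to 40000 nM, and the assay may well report only a limit for it.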

Compound 3, half-maximal inhibitory concentration: > 31600 nM
Compound 3: no number, only a limit; the forecaster's own chance of this, stated with the estimate: 45%; middle value at least 5.2-fold (0.72 log units) away from the limit.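

In this assay, hydrogen in place of acetoxy on a saturated chain carbon bound to an aromatic carbon gives an at least 810-fold higher number from compound 2 to compound 3 (2.90 log units; beyond the scatter), so this one change, acetoxymethyl to methyl, is enough to take the series from a measured number to a limit. The earlier step compared acetoxy only with hydroxymethyl, whereas this one shows that the shared core with a bare methyl at this place does not keep the number of compound 2 either, and among the three compounds shown, only the one carrying acetoxy gives a number. Compound 1 and compound 3 cannot be set against each other, and the step between them cannot be read, because both stand at a limit: the limit of > 31600 nM in this assay, at which 2 of the 3 values shown sit.

The compounds shown leave open whether the ester itself matters or whether other groups at this place would also give a number, such as a methoxy group, which keeps an oxygen but has no carbonyl, or an acetamide, which has nitrogen in place of the ester oxygen. They also leave open how a longer ester, such as propionyloxy or benzoyloxy, would read in this assay.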